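A Smaller Aromatic Ring on the Shared Core

A few compounds are considered here, and "the series" means these few. Any claim that something is new, unique, unknown or untested is made for them only; others in the source may bear on it.

compound 1 `O=C(O)Cc1sc(COc2ccc(Cl)cc2)nc1-c1ccc(Cl)cc1` — 50%
compound 2 `N#Cc1cc(-c2nc(C(c3ccc(F)cc3)c3ccc(F)cc3)sc2CC(=O)O)ccc1F` — 80%
compound 3 `O=C(O)Cc1sc(C(c2ccccc2)c2ccccc2)nc1-c1ccc(C(F)(F)F)cc1` — 80%

These three compounds were tested in an in vitro functional assay on HEK285-7 cells for antagonist activity at prostaglandin D2 receptor 2 (Homo sapiens), read by BRET and beta-arrestin recruitment; a higher number here means a larger maximal response, a lower number a smaller maximal response. Compound 2 and compound 3 stand level at the digits shown, together the highest of the three numbers, while compound 1 gives a clearly lower number, beyond the scatter. Compound 4 `O=C(O)Cc1sc(C(c2ccc(F)cc2)c2ccc(F)cc2)nc1-c1ccoc1` has not yet been measured. It differs from compound 2 in one place: furan-3-yl in place of 3-cyano-4-fluorophenyl on an aromatic carbon. For the measured compounds named here, no measured pair shows this change on its own, so its size is uncertain; the three measured compounds all carry a six-membered aromatic ring of carbon only at this place. Compound 4 is expected to show a small decrease, a number 10 percentage points lower from compound 2 to compound 4 (within the scatter), likely within the scatter, because compound 2 gives 80%. Compound 4 is estimated at 70%, ranging from 45% to 90%.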

Compound 4, largest response reached (reported as efficacy), in percent of the reference or control that the assay uses: 80%
Estimate against measurement, compound 4: 10 percentage points below; the measured number falls inside the stated range.
By their numbers in this assay, from the lowest: compound 1; then compounds 2, 3 and 4 (each within the scatter of the next).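

Swapping 3-cyano-4-fluorophenyl for furan-3-yl in this assay gives no change at the digits printed from compound 2 to compound 4 (within the scatter). The earlier compounds shown here all carried a six-membered aromatic ring of carbon only at this place, next to the ring nitrogen, whereas compound 4 shows that a smaller five-membered aromatic ring with 1 hetero atom, without the nitrile and the fluorine, can sit there with the number level. Nothing available explains why the number holds.

Still open, going by these compounds, is whether a non-aromatic group at this place, such as an amine or a short alkyl chain, would hold the number too. Whether an aromatic ring is needed here at all therefore remains unanswered.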